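A few compounds are considered here, and "the series" means these few. Any claim that something is new, unique, unknown or untested is made for them only; others in the source may bear on it.

In a functional assay for inhibition, with Homo sapiens as the target (a higher number here means a weaker inhibitor, a lower number a stronger inhibitor), three compounds have been measured: compound 1 `c1coc(-c2ccnc(Nc3ccc(-n4ccnc4)cc3)n2)c1` gives 2200 nM; compound 2 `COc1cccc(Nc2nccc(-c3ccsc3)n2)c1` gives 1800 nM; compound 3 `c1ccc(-c2ccnc(Nc3ccc(-n4ccnc4)cc3)n2)nc1` gives 1400 nM.

Compound 2 stands second highest of these three numbers, within the scatter of both compound 1 and compound 3. Compound 4 `COc1cccc(Nc2nccc(-c3ccncc3)n2)c1` differs from it in one place: pyridin-4-yl in place of thiophen-3-yl on an aromatic carbon. For the measured compounds named here, one measured step bears on this, the exchange of one five-membered aromatic ring for a six-membered aromatic ring seen in a 1.6-fold lower number from compound 1 to compound 3 (0.20 log units; within the scatter); that step stayed within the scatter. On that basis no step beyond the scatter is expected in this assay for compound 4, whose value is estimated at 1500 nM, between 600 nM and 4000 nM, which would mean a 1.2-fold lower number from compound 2 to compound 4 (0.08 log units; within the scatter).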

Compound 4, half-maximal inhibitory concentration: 400 nM
Compound 4: middle estimate off by 3.8-fold (0.57 log units), on the high side; measured number below the stated range.
By their numbers in this assay, from the lowest: compound 4; then compounds 3, 2 and 1 (each within the scatter of the next).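

In this assay, pyridin-4-yl in place of thiophen-3-yl gives a 4.5-fold lower number from compound 2 to compound 4 (0.65 log units; beyond the scatter). This position therefore responds to the exchange of a five-membered aromatic ring for a six-membered one by a step beyond the scatter, which the earlier step, a 1.6-fold lower number from compound 1 to compound 3 (0.20 log units; within the scatter), did not show. No measurement shown accounts for this step. The compounds shown leave open whether pyridin-3-yl or plain phenyl at this position would match compound 4. They also leave open whether a non-aromatic group, such as morpholine or a primary amine, would be tolerated there.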